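The source may report more compounds than this note shows. Statements on the series, on what has been measured and on what is new or still open speak of the compounds shown alone.

Compound 1 `COc1cc(/C=N/Nc2nc(-c3ccc(F)c(F)c3)cs2)cc(Br)c1OC` gives 26300 nM in a functional assay on U-87MG ATCC cells for inhibition, with U-87 MG (Homo sapiens) as the target, read by MTT assay, with a stated time of 48 h (a higher number here means a weaker inhibitor, a lower number a stronger inhibitor), the highest of the two numbers measured; compound 2 `COc1cc(/C=N/Nc2nc(-c3ccc(F)c(F)c3)cs2)c(Br)c(Br)c1OC` gives 19600 nM in this assay, and a 1.3-fold lower number from compound 1 to compound 2 (0.13 log units; within the scatter) lies within the scatter. Compound 3 `COc1cc(/C=N/Nc2nc(-c3ccccc3)cs2)cc(Br)c1OC` differs from compound 1 by phenyl in place of 3,4-difluorophenyl on an aromatic carbon. Among the compounds with values here, no measured step touches that part of the shared core; the only step known, a 1.3-fold lower number from compound 1 to compound 2 (0.13 log units; within the scatter), concerns a bromo group and was small, so no step beyond the scatter is expected in this assay. Compound 3 is therefore estimated at 30000 nM, with a range from 12000 nM to 80000 nM, which means a 1.1-fold higher number from compound 1 to compound 3 (0.06 log units; within the scatter) is expected.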

Compound 3, half-maximal inhibitory concentration: 74100 nM
The estimate for compound 3 lay 2.5-fold (0.39 log units) below the measured number; measured number inside the range.
By their numbers in this assay, from the lowest: compounds 2 and 1 (each within the scatter of the next); then compound 3.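

Phenyl in place of 3,4-difluorophenyl, on the aromatic carbon next to the ring nitrogen, gives a 2.8-fold higher number from compound 1 to compound 3 (0.45 log units; beyond the scatter) in this assay. This is the first step beyond the scatter among these compounds, so the group at this position affects the number more than the bromo change did. Nothing available explains this step. The compounds shown leave open whether a single fluoro group would keep the lower number of compound 1, and how an amine on that phenyl ring would read. They also leave open whether the step would hold alongside the second bromo of compound 2.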